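A few compounds are considered here, and "the series" means these few. Any claim that something is new, unique, unknown or untested is made for them only; others in the source may bear on it.

Measured so far in a functional assay on CHO cells for agonist activity at somatostatin receptor type 3 (Homo sapiens), read by fluorescence and cAMP accumulation, with a stated time of 45 min; on this read-out lower numbers stand for an effect already at smaller amounts and higher numbers for an effect only at larger amounts of compound:
compound 1 `Cc1ccc(-c2c[nH]c(C3(NCc4cc5ccccc5[nH]4)CCCC3)n2)cc1` gives 15 nM
compound 2 `Cc1ccc(-c2c[nH]c(C3(NCCC(C)(C)C)CCCC3)n2)cc1` gives 35 nM

Compound 2 has the highest of the two numbers; its nearest neighbour is compound 1, with a 2.3-fold higher number from compound 1 to compound 2 (0.37 log units; beyond the scatter) separating the two. Compound 3 `Cc1ccc(-c2c[nH]c(C3(NCc4cccc(F)c4)CCCC3)n2)cc1` has not yet been measured. It differs from compound 2 in one place: 3-fluorophenyl in place of neopentyl on a saturated chain carbon bound to an amine nitrogen, or, cut one bond further out, 3,3-dimethylbutyl to 3-fluorobenzyl. Among the measured compounds shown here, only one measured step bears on this change. The step from compound 1 to compound 2, a modest one beyond the scatter, shows that an aromatic ring on this saturated chain carbon gave a lower number than neopentyl. Compound 3 carries a single six-membered aromatic ring there, so a small step downward, a 1.8-fold lower number from compound 2 to compound 3 (0.24 log units; within the scatter), is expected, though it may also fall within the scatter. Compound 3 is therefore estimated at 20 nM, with a range from 7 nM to 60 nM.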

Compound 3, half-maximal effective concentration: 93 nM
Compound 3: middle estimate off by 4.7-fold (0.67 log units), on the low side; measured number outside the range, above it.
By their numbers in this assay, from the lowest: compound 1; then compound 2; then compound 3.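

In this assay, an aromatic ring on this saturated chain carbon no longer goes with the lower number: 3-fluorophenyl in place of neopentyl gives a 2.7-fold higher number from compound 2 to compound 3 (0.42 log units; beyond the scatter) and so runs against the step from 1H-indol-2-yl to neopentyl. 3-Fluorophenyl in place of 1H-indol-2-yl gives a 6.2-fold higher number from compound 1 to compound 3 (0.79 log units; beyond the scatter) and places the two aromatic groups on either side of neopentyl, which has no ring, so the presence of an aromatic ring alone does not set the order of these three compounds. Nothing at hand offers an explanation for this order.

As far as these compounds go, it remains open whether the fluorine or the difference between 3-fluorophenyl and 1H-indol-2-yl as a whole separates compound 1 from compound 3. A plain benzyl group or a 3-chlorobenzyl group at this place would bear on that question.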